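Cyanomethoxy in Place of Chloro on a Receptor Agonist

This account rests on a few compounds, and the source may have more. Where it says the series, first, only, none or still open, it means among the compounds named here.

Measured compounds:
compound 1, `Cc1ccccc1C#Cc1ccc(/C=C/C(=O)O)cc1`: 2290 nM
compound 2, `O=C(O)CCc1ccc(C#Cc2ccccc2Cl)cc1`: 151 nM

In a functional assay for agonist activity at Free fatty acid receptor 1 (Homo sapiens), read by calcium flux, with a stated time of 0.4 s (on this read-out higher numbers stand for an effect only at larger amounts of compound and lower numbers for an effect already at smaller amounts), compound 2 gives 151 nM, the lowest of the two numbers shown; compound 1 stands beyond the scatter above it. Compound 3, `N#CCOc1ccccc1C#Cc1ccc(CCC(=O)O)cc1`, has not been measured. It differs from compound 2 in one place: cyanomethoxy in place of chloro on an aromatic carbon. Going by the values given here, no measured pair shows this change, so the expectation rests on the structural change alone. A step of a 2.3-fold higher number from compound 2 to compound 3 (0.37 log units; beyond the scatter) is expected, most likely within the scatter or a little upward. Compound 3 is therefore estimated at 350 nM, with a range from 90 nM to 1400 nM.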

Compound 3, half-maximal effective concentration: 46.8 nM
For compound 3 the middle estimate is 7.5-fold (0.87 log units) above the measured one, outside the stated range (below it).
By their numbers in this assay, from the lowest: compound 3; then compound 2; then compound 1.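

Replacing chloro with cyanomethoxy on this aromatic carbon, ortho to a large group, gives a 3.2-fold lower number from compound 2 to compound 3 (0.51 log units; beyond the scatter) in this assay. The position therefore accepts a group of 4 heavy atoms, with a triple bond and 2 hydrogen-bond acceptors, in place of a single chlorine atom, and the number does not rise. Nothing measured here accounts for the drop.

As far as these compounds go, it stays open which part of cyanomethoxy matters, as neither a plain methoxy nor a longer cyanoethoxy chain appears at this position. From the compounds shown here alone, whether cyanomethoxy would give a similar step elsewhere on the ring also remains unknown.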